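Ethoxy to propargyloxy: working notes on compound 3

The source may report more compounds than this note shows. Statements on the series, on what has been measured and on what is new or still open speak of the compounds shown alone.

Measured so far in a functional assay on A549 cells (Homo sapiens) for inhibition, read by sulforhodamine B assay, with a stated time of 48 h, tested at 50 uM (a lower number here means less inhibition of growth, a higher number more inhibition of growth at the concentration tested), for two compounds

- compound 1 `COc1cc2c(cc1CC=C(C)C)C(=O)C[C@@H](c1ccc(Oc3ccc(F)cc3)cc1)O2` gives 27%
- compound 2 `CCOc1ccc([C@@H]2CC(=O)c3cc(CC=C(C)C)c(OC)cc3O2)cc1` gives 37%

Compound 2 at 37% lies within the scatter of compound 1, so the pair cannot be ranked.

Next comes compound 3 `C#CCOc1ccc([C@@H]2CC(=O)c3cc(CC=C(C)C)c(OC)cc3O2)cc1` with ethynyl in place of methyl on a saturated chain carbon bound to an oxygen on an aromatic ring, which reads as ethoxy to propargyloxy. The counted difference is ethynyl in place of methyl on a saturated chain carbon bound to an oxygen on an aromatic ring in this one place. Within the data shown here, the only measured step bearing on this change, a number 10 percentage points higher from compound 1 to compound 2 (within the scatter), also swaps the group on an oxygen on an aromatic ring. That is a thin basis, and it gives no direction. No step beyond the scatter is therefore expected in this assay for this change. The estimated step is a number 2 percentage points lower from compound 2 to compound 3 (within the scatter) on this reasoning. For compound 3 the expected value is 35% as a central estimate, with an estimated range from 20% to 50% in this read-out.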

Compound 3, percent growth inhibition at one concentration: 53%
Compound 3: middle estimate off by 18 percentage points, on the low side, and the stated range ends below it.
By their numbers in this assay, from the lowest: compounds 1 and 2 (each within the scatter of the next); then compound 3.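

In this assay, the group on this oxygen now gives a readable difference: ethoxy to propargyloxy is a number 16 percentage points higher from compound 2 to compound 3 (beyond the scatter), whereas compound 1 and compound 2 could not be ranked. Propargyl in place of 4-fluorophenyl also reads, at a number 26 percentage points higher from compound 1 to compound 3 (beyond the scatter), so compound 3 stands apart from both other compounds, and this place on the series responds to the group it carries. No measurement available here speaks to the reason for this gain.

On these data alone, whether the gain follows the triple bond or simply the added carbon remains open, and a saturated propyl group on the same oxygen would separate the two. Also open, as far as these compounds go, is how a longer chain, or a chain carrying an amine or a carboxylic acid, would read at this place.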